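Changing the Outer Ring of a Beta-Glucosidase Inhibitor

The compounds below may be only part of what the source reports. "The series", "measured", "known", "first", "only" and "open" are said of these compounds alone.

Compound 1 `COc1ccc(-c2ccc(COCCCCCN3C[C@H](O)[C@@H](O)[C@H](O)[C@H]3CO)cc2)cc1` is the starting point. Among the measured compounds shown here, in an assay on isolated protein for inhibition of Beta-glucosidase (Homo sapiens) (a higher number here means a weaker inhibitor, a lower number a stronger inhibitor), compound 1 gives 10 nM, which places it second highest among the three numbers known here. Compound 2 `COc1ccccc1-c1ccc(COCCCCCN2C[C@H](O)[C@@H](O)[C@H](O)[C@H]2CO)cc1` gives 3 nM, and compound 3 `OC[C@@H]1[C@@H](O)[C@H](O)[C@@H](O)CN1CCCCCOCc1ccc(-c2ccc3c(c2)OCCO3)cc1` gives 30 nM. Putting 2-methoxyphenyl in place of 4-methoxyphenyl gave a 3.3-fold lower number from compound 1 to compound 2 (0.52 log units; beyond the scatter), while putting 2,3-dihydro-1,4-benzodioxin-6-yl in its place gave a 3.0-fold higher number from compound 1 to compound 3 (0.48 log units; beyond the scatter). Compound 4 `OC[C@@H]1[C@@H](O)[C@H](O)[C@@H](O)CN1CCCCCOCc1ccc(-c2ccc(F)nc2)cc1` differs from compound 1 in one place: 6-fluoropyridin-3-yl in place of 4-methoxyphenyl on an aromatic carbon. Neither measured step tests this change directly, since both keep a carbon-only ring carrying oxygen, whereas compound 4 brings in a ring with a nitrogen and a fluorine. The two known steps show that changes at this position shift the number by modest amounts in either direction, so a modest step is expected here as well, leaning toward a somewhat higher number. Compound 4 is therefore estimated at 20 nM, within 6 nM to 70 nM. That estimate amounts to an expected 2.0-fold higher number from compound 1 to compound 4 (0.30 log units; within the scatter).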

Compound 4, half-maximal inhibitory concentration: 5 nM
The estimate for compound 4 lay 4.0-fold (0.60 log units) above the measured number; measured number below the stated range.
By their numbers in this assay, from the lowest: compounds 2, 4 and 1 (each within the scatter of the next, the first and the last beyond it); then compound 3.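

In this assay, the outer ring can take a nitrogen and a fluorine in place of a carbon-only ring carrying oxygen with no step beyond the scatter: 6-fluoropyridin-3-yl in place of 4-methoxyphenyl gave a 2.0-fold lower number from compound 1 to compound 4 (0.30 log units; within the scatter) and in place of 2-methoxyphenyl gave a 1.7-fold higher number from compound 2 to compound 4 (0.22 log units; within the scatter) in the same assay. Replacing 2,3-dihydro-1,4-benzodioxin-6-yl with the same ring is a clearer change, with a 6.0-fold lower number from compound 3 to compound 4 (0.78 log units; beyond the scatter) as the result, so the fluoropyridine ring groups with the two methoxyphenyl rings rather than with the benzodioxin. No measurement available here explains these differences.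

On these data alone, the nitrogen and the fluorine enter together, so their separate contributions remain open; a pyridin-3-yl ring without fluorine and a 4-fluorophenyl ring would pull them apart. As far as these compounds go, how an amine or a carboxylic acid on this ring would read is also open.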